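This account rests on a few compounds, and the source may have more. Where it says the series, first, only, none or still open, it means among the compounds named here.

Compounds measured so far in a functional assay on T-24 cells (Homo sapiens) for antiproliferative activity, read by MTT assay, with a stated time of 48 h; a lower number here means a stronger inhibitor, a higher number a weaker inhibitor:
compound 1 `O=C(Nc1cccc(Cl)c1)Nc1cccc(CNc2nccnc2Cl)c1` gives 6810 nM
compound 2 `Cc1cccc(NC(=O)Nc2cccc(CNc3nccnc3Cl)c2)c1` gives 9570 nM
compound 3 `Cc1ccc(NC(=O)Nc2cccc(CNc3nccnc3Cl)c2)cc1Cl` gives 7390 nM

Compound 1 holds the lowest of the three numbers, yet the step of a 1.1-fold higher number from compound 1 to compound 3 (0.04 log units; within the scatter) and the step of a 1.4-fold higher number from compound 1 to compound 2 (0.15 log units; within the scatter) both stay within the scatter, so no ranking among the three can be drawn. Compound 4 `O=C(Nc1cccc(CNc2nccnc2Cl)c1)Nc1ccc(Cl)c(Cl)c1` is not yet measured. Its difference from compound 1 is chloro in place of hydrogen on an aromatic carbon.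

The step most comparable to this one is a 1.1-fold higher number from compound 1 to compound 3 (0.04 log units; within the scatter), where a methyl rather than a chloro entered the same aryl position; it changed nothing beyond the scatter. The step of a 1.3-fold lower number from compound 2 to compound 3 (0.11 log units; within the scatter) likewise shows that adding a chloro to the aryl ring bearing a methyl left the number essentially unchanged. Given this, the expectation for this assay is a step of a 1.0-fold lower number from compound 1 to compound 4 (0.02 log units; within the scatter) from compound 1, that is, no change beyond the scatter. Compound 4 is therefore estimated at 6500 nM, with a range from 3200 nM to 13500 nM.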

Compound 4, half-maximal inhibitory concentration: 5210 nM
The estimate for compound 4 lay 1.2-fold (0.10 log units) above the measured number; the range from low to high includes it.
By their numbers in this assay, from the lowest: compounds 4, 1, 3 and 2 (each within the scatter of the next).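

In this assay, chloro in place of hydrogen on the aromatic carbon ortho to the existing chloro group and para to a large group gives a 1.3-fold lower number from compound 1 to compound 4 (0.12 log units; within the scatter), so adding this second chloro shifts nothing beyond the scatter. With a 1.4-fold lower number from compound 3 to compound 4 (0.15 log units; within the scatter) for chloro in place of methyl at that same carbon, and a 1.8-fold lower number from compound 2 to compound 4 (0.26 log units; within the scatter) for 3,4-dichlorophenyl in place of 3-methylphenyl, hydrogen, methyl and chloro on this ring cannot be told apart here. Methyl in place of chloro also reads alike on two cores: the same change on two cores in this assay, a 1.4-fold higher number (0.15 log units; within the scatter) from compound 1 to compound 2 and a 1.4-fold higher number (0.15 log units; within the scatter) from compound 4 to compound 3, 1.0-fold (0.00 log units) apart, within the scatter of two such steps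

As far as these compounds go, only hydrogen, methyl and chloro appear at this carbon, so the effect of an amine, a methoxy group or a carboxylic acid there remains open. From the compounds shown here alone, whether any change on this ring can move the number beyond the scatter also remains open.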